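Trifluoromethyl in place of fluoro on compound 3

The source may hold more compounds than are shown below. What is called first, only, known or untested is meant among the compounds shown, and "the series" means these compounds.

In a functional assay on HeLa cells (Homo sapiens) for antiproliferative activity, read by MTT assay, with a stated time of 24 h (on this read-out higher numbers stand for weaker inhibition and lower numbers for stronger inhibition), compound 1 (`O=S(=O)(c1ccccc1)n1c(-c2cn(-c3ccccc3)nc2-c2ccc(F)cc2)nc2ccccc21`) gives 680 nM, compound 2 (`O=[N+]([O-])c1ccc(S(=O)(=O)n2c(-c3cn(-c4ccccc4)nc3-c3ccc(F)cc3)nc3ccccc32)cc1`) gives 1170 nM and compound 3 (`O=S(=O)(c1ccc(F)cc1)n1c(-c2cn(-c3ccccc3)nc2-c2ccc(F)cc2)nc2ccccc21`) gives 2440 nM. Compound 3 has the highest number of the three and is the weakest inhibitor here. Its gaps to the others are a 2.1-fold higher number from compound 2 to compound 3 (0.32 log units; beyond the scatter) and a 3.6-fold higher number from compound 1 to compound 3 (0.55 log units; beyond the scatter), both modest, while a 1.7-fold higher number from compound 1 to compound 2 (0.24 log units; within the scatter) stays within the scatter.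

Compound 4 (`O=S(=O)(c1ccc(F)cc1)n1c(-c2cn(-c3ccccc3)nc2-c2ccc(C(F)(F)F)cc2)nc2ccccc21`) differs from compound 3 in one place: trifluoromethyl in place of fluoro on an aromatic carbon. This is trifluoromethyl in place of fluoro on an aromatic carbon, para to a large group, and reads as 4-fluorophenyl to 4-(trifluoromethyl)phenyl.

Within the data shown here, all three measured compounds carry the 4-fluorophenyl group unchanged, so no measured step reports on this exchange directly. The three steps bear on it only as a guide to size, since each is a single replacement on an aromatic carbon elsewhere in the structure and none exceeds the modest 3.6-fold higher number from compound 1 to compound 3 (0.55 log units; beyond the scatter). They give no direction for the new step, and no change beyond the scatter is expected. The expected step is a 1.2-fold lower number from compound 3 to compound 4 (0.09 log units; within the scatter). For compound 4 the estimated value is 2000 nM, with an expected range of 700 nM to 5500 nM.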

Compound 4, half-maximal inhibitory concentration: 2190 nM
The estimate for compound 4 lay 1.1-fold (0.04 log units) below the measured number; the range from low to high includes it.
By their numbers in this assay, from the lowest: compounds 1, 2, 4 and 3 (each within the scatter of the next, the first and the last beyond it).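

In this assay, among these compounds, the new pair gives the first direct reading at the 4-fluorophenyl group, which stayed unchanged across the earlier compounds: a 1.1-fold lower number from compound 3 to compound 4 (0.05 log units; within the scatter). Going from 4-fluorophenyl to 4-(trifluoromethyl)phenyl replaces a group of 1 heavy atom with one of 4 on the aromatic carbon para to a large group, and this larger group produces no step that can be resolved from the scatter, so on this background the position accepts both groups in this read-out. No supporting measurement bears on why the two compounds cannot be told apart, so the result stands as an observation only.

A single exchange on the background of compound 3 leaves open whether the same result would hold with the unsubstituted group of compound 1 in place of the fluoro-bearing one elsewhere in the structure. It also leaves open whether a group of another kind at this position, such as an amine, a carboxylic acid or a longer alkyl chain, would give a step beyond the scatter.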